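A few compounds are considered here, and "the series" means these few. Any claim that something is new, unique, unknown or untested is made for them only; others in the source may bear on it.

- compound 1 `COc1ccc(C2=[N+]3C(=Nc4c(-c5ccccc5)c5c(n4[B-]3(F)F)-c3ccc(OCC(=O)O)cc3CC5)C(c3ccccc3)=C2I)cc1`: > 50000 nM (a limit)
- compound 2 `COc1ccc(C2=[N+]3C(=Nc4c(-c5ccccc5)c5c(n4[B-]3(F)F)-c3ccc(OCC(=O)N[C@@H](CC(=O)O)C(=O)O)cc3CC5)C(c3ccccc3)=C2I)cc1`: > 250000 nM (a limit)

Both values come from a functional assay on HeLa cells (Homo sapiens) for cytotoxicity, read by CCK-8 assay, with a stated time of 16 h; a lower number here means a stronger inhibitor, a higher number a weaker inhibitor. Compound 2 gives > 250000 nM, which is a limit and not a number, so it has no exact place on the scale. Compound 1 likewise gives only a limit, > 50000 nM.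

Compound 3 `COc1ccc(C2=[N+]3C(=Nc4c(-c5ccccc5)c5c(n4[B-]3(F)F)-c3ccc(OCC(=O)N[C@@H](CCC(=O)O)C(=O)O)cc3CC5)C(c3ccccc3)=C2I)cc1` carries carboxymethyl in place of carboxy on a saturated chain carbon, two bonds along the chain from an amide-type nitrogen and a carbonyl carbon. Put another way, 1,2-dicarboxyethyl becomes 1,3-dicarboxypropyl.

For the measured compounds named here, the only measured step is a step that the two limits leave unreadable from compound 1 to compound 2, so it offers no size to carry over. With no measured guide, no shift beyond the scatter is expected in this assay, and a further limit is the likely report. The expected step is a number no higher from compound 2 to compound 3 (the limit leaves the size open). Compound 3 is estimated at 250000 nM, within an expected range of 120000 nM to 500000 nM.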

Compound 3, half-maximal inhibitory concentration: > 250000 nM
Compound 3: no number, only a limit; the forecaster's own chance of this, stated with the estimate: 85%; the middle value lies on the limit itself.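

For the compounds shown here, compound 1, compound 2 and compound 3 are each reported only as a limit, so no step among them can be read. The compounds shown leave open what exact value any of them has in this assay, and whether replacing carboxy with carboxymethyl changes it.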